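The compounds below may be only part of what the source reports. "The series", "measured", "known", "first", "only" and "open" are said of these compounds alone.

Compound 1, `CCC[C@@H]1O[C@H](COCc2ccc3ccccc3c2)[C@@H](OCc2ccc3ccccc3c2)[C@H](OCc2ccc3ccccc3c2)[C@H]1O`, in a functional assay on HOS cells (Homo sapiens) for antiproliferative activity, read by sulforhodamine B assay; a lower number here means a stronger inhibitor of growth, a higher number a weaker inhibitor of growth: > 50000 nM, which is a limit of the assay and not a number.
Compound 2, `CCC[C@@H]1O[C@H](COCc2ccc3ccccc3c2)[C@@H](OCc2ccc3ccccc3c2)[C@H](OCc2ccc3ccccc3c2)[C@H]1OC(C)=O`, in this assay: > 50000 nM, which is also a limit of the assay and not a number.
Compound 3, `CC(C)C[C@H]1O[C@H](COCc2ccccc2)[C@@H](OCc2ccccc2)[C@H](OCc2ccccc2)[C@H]1O`, in this assay: 44500 nM.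

Compound 1 and compound 2 share one core, and compound 2 differs from compound 1 only by acetyl in place of hydrogen on an oxygen on a saturated carbon. The step that the two limits leave unreadable from compound 1 to compound 2 cannot be sized because of the limit of > 50000 nM in this assay, at which 2 of the 3 values shown sit. So the measured pair tells nothing about how large or how small the effect of the acetyl group is.

Compound 4, `CC(=O)O[C@@H]1[C@@H](OCc2ccccc2)[C@H](OCc2ccccc2)[C@@H](COCc2ccccc2)O[C@@H]1CC(C)C`, has not yet been tested. It differs from compound 3 by acetyl in place of hydrogen on an oxygen on a saturated carbon. This is the same change as that from compound 1 to compound 2, set in the same surroundings. The difference between the core of compound 3 and the core of compound 1 is not broken down here.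

Compound 3 gives a number, 44500 nM, that already shows only weak inhibition of growth in this assay. Among the compounds with values here, since the one measured example of the acetyl change gives no readable size, the expected step of a 1.1-fold higher number from compound 3 to compound 4 (0.05 log units; within the scatter) from compound 3 to compound 4 is taken as small. Compound 4 is therefore estimated at 50000 nM, with an expected range from 20000 nM to 150000 nM. There is a fair chance that compound 4, like compound 1 and compound 2, will return only a limit of the assay rather than a number.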

Compound 4, concentration for 50% growth inhibition: > 50000 nM
Compound 4: no number, only a limit (the forecaster's own chance of this, stated with the estimate: 55%); the middle value lies on the limit itself.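

In this assay compound 4 gives > 50000 nM, which is a limit of the assay and not a number. Going by these compounds, the acetyl change on the core of compound 3 can therefore be read only as an at least 1.1-fold higher number from compound 3 to compound 4 (0.05 log units; that floor lies within the scatter), so going from hydroxy to acetoxy here gives no sign of stronger inhibition of growth, while how much weaker compound 4 may be remains unknown. The same change on the core of compound 1 cannot be read at all, so the size of the step cannot be compared between the two cores, and all that carries across is that both acetyl compounds end at the same limit: the limit of > 50000 nM in this assay, at which 3 of the 4 values shown sit.

The compounds shown leave open what a different group on that oxygen would do, for example a longer chain such as butanoyl, or a chain ending in an amine or a carboxylic acid, and whether any of these would shift the reading clearly away from that of compound 3, 44500 nM. They also leave open whether a plain methyl ether in place of the hydroxy would read any differently from the acetoxy of compound 4.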